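The compounds below may be only part of what the source reports. "The series", "measured", "known", "first", "only" and "open" are said of these compounds alone.

Measured so far:
Compound 1, `C/C(=C\COc1ccc2ccccc2c1)CC/C=C(\C)C1CC(=O)C(C)(C)O1`: 24.9 ug/mL
Compound 2, `C/C(=C\COc1ccccc1)CC/C=C(\C)C1=CC(=O)C(C)(C)O1`: 38.7 ug/mL

In a functional assay on L1210 cells (Mus musculus) for inhibition (on this read-out higher numbers stand for weaker inhibition and lower numbers for stronger inhibition), compound 1 gives 24.9 ug/mL, and compound 2 gives 38.7 ug/mL; the two numbers lie within the scatter of each other, so neither is set apart. Compound 3, `C/C(=C\COc1ccc2ccccc2c1)CC/C=C(\C)C1=CC(=O)C(C)(C)O1`, is not yet measured. It differs from compound 1 by a group of 8 heavy atoms (6 carbon, 2 oxygen; one five-membered non-aromatic ring with 1 hetero atom) in place of a group of 8 heavy atoms (6 carbon, 2 oxygen; one five-membered non-aromatic ring with 1 hetero atom), on a double-bonded chain carbon bound to a double-bonded chain carbon and a saturated chain carbon. Going by the values given here, no pair of measured compounds differs in a single place, so no measured step guides the expectation. Since compound 3 carries the same ring as compound 2, and compound 2 gives 38.7 ug/mL, the step of a 1.2-fold higher number from compound 1 to compound 3 (0.08 log units; within the scatter) is expected to stay within the scatter. Compound 3 is therefore expected to give 30 ug/mL, in the range 12 ug/mL to 75 ug/mL.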

Compound 3, half-maximal inhibitory concentration: 47.4 ug/mL
Estimate against measurement, compound 3: 1.6-fold (0.20 log units) below; the measured number falls inside the stated range.
By their numbers in this assay, from the lowest: compounds 1, 2 and 3 (each within the scatter of the next).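

In this assay, going by these compounds alone, replacing the 5,5-dimethyl-4-oxooxolan-2-yl group with a ring of the same size that has one more double bond gives the first step that can be read at this place (a 1.9-fold higher number from compound 1 to compound 3 (0.28 log units; within the scatter)). The extra double bond therefore does not set the two compounds apart, and neither ring stands out on this evidence. Nothing available on these compounds bears on this result. Still open, as far as these compounds go, is how a quite different group on this chain carbon, such as an amine or a carboxylic acid, would read.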